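Chloro in place of fluoro on compound 2

The source may report more compounds than this note shows. Statements on the series, on what has been measured and on what is new or still open speak of the compounds shown alone.

Of the compounds shown here, two have been measured so far in an ADME assay on J774 cells (Mus musculus) for cytotoxicity (on this read-out lower numbers stand for an effect already at smaller amounts and higher numbers for an effect only at larger amounts of compound), and only one of them has a number. Compound 1 `CCCCC#Cc1c(C)[nH]c2ccc(Cl)cc2c1=O` is reported with the limit > 36300 nM and nothing more. Among the measured compounds shown here, compound 2 `CCc1c(C)[nH]c2cc(OC)c(F)cc2c1=O` gives 9400 nM as the only actual number, so its standing cannot yet be set against a second measured value. Compound 3 `CCc1c(C)[nH]c2cc(OC)c(Cl)cc2c1=O` differs from compound 2 in one place chloro in place of fluoro on an aromatic carbon with chloro in place of fluoro on an aromatic carbon, ortho to a methoxy group. For the measured compounds named here, no measured pair shows what such an exchange does in this assay so the expectation stays modest. The expected change a 1.0-fold lower number from compound 2 to compound 3 (0.02 log units; within the scatter) lies within the usual scatter, with no firm direction. For compound 3 the estimated value is 9000 nM with an expected range from 3500 nM to 25000 nM here.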

Compound 3, half-maximal effective concentration: 19000 nM
For compound 3 the middle estimate is 2.1-fold (0.32 log units) below the measured one; the measured number falls inside the stated range.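

In this assay, this aromatic carbon, ortho to a methoxy group, proves sensitive to the halogen it carries: chloro in place of fluoro gives a 2.0-fold higher number from compound 2 to compound 3 (0.31 log units; beyond the scatter). Among the compounds shown here, this is the only measured pair so far, so the exchange now has a direction, with the chloro compound acting only at larger amounts of compound, although that direction rests on this single modest step. The data shown offer no measured property that would explain why the number moves.

Compound 1 is reported only as a limit, > 36300 nM, and it differs from the others in more than one place, so it says nothing about this position. As far as these compounds go, it remains open whether bromo, a nitrile or an amine on the same carbon would carry the number further, and whether the step from fluoro to chloro would hold on a different chain.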